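From tert-butylphenyl to chlorophenyl on the amide nitrogen

This account rests on a few compounds, and the source may have more. Where it says the series, first, only, none or still open, it means among the compounds named here.

Compound 1 `COc1cc2ncnc(NCc3cccc(NC(=O)Nc4ccccc4C)c3)c2cc1OC` gives > 50000 nM in a functional assay on MGC-803 cells (Homo sapiens) for antiproliferative activity, read by MTT assay (on this read-out higher numbers stand for weaker inhibition and lower numbers for stronger inhibition), which is a limit of the assay rather than a number.
Compound 2 `COc1ccc(NC(=O)Nc2cccc(CNc3ncnc4cc(OC)c(OC)cc34)c2)cc1` gives 12300 nM in this assay.
Compound 3 `COc1cc2ncnc(NCc3cccc(NC(=O)Nc4ccc(C(C)(C)C)cc4)c3)c2cc1OC` gives 6790 nM in this assay.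

Compound 3 holds the lowest of the two numbers shown, but its separation from compound 2 is only a 1.8-fold lower number from compound 2 to compound 3 (0.26 log units; within the scatter), so the two cannot be ranked against each other. Compound 1 stands apart at the limit of > 50000 nM in this assay, at which 1 of the 3 values shown sits. The two steps away from compound 1 are both clear: an at least 4.0-fold lower number from compound 1 to compound 2 (0.60 log units; beyond the scatter) and an at least 7.3-fold lower number from compound 1 to compound 3 (0.86 log units; beyond the scatter).

Compound 4 `COc1cc2ncnc(NCc3cccc(NC(=O)Nc4ccccc4Cl)c3)c2cc1OC` differs from compound 3 in one place: 2-chlorophenyl in place of 4-(tert-butyl)phenyl on an amide-type nitrogen. For the measured compounds named here, no measured step covers this exact exchange. The closest guide is compound 1, which carries 2-methylphenyl on that same amide-type nitrogen and sits at the limit, whereas compound 2 and compound 3 carry 4-methoxyphenyl and 4-(tert-butyl)phenyl and give numbers. Compound 4, with 2-chlorophenyl, resembles compound 1 more closely than it resembles compound 2 or compound 3, so a higher number in this assay is expected, and a limit is quite possible. The step is estimated at a 5.9-fold higher number from compound 3 to compound 4 (0.77 log units; beyond the scatter). Compound 4 is therefore expected to give about 40000 nM, within 12000 nM to 150000 nM.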

Compound 4, half-maximal inhibitory concentration: 30200 nM
The estimate for compound 4 lay 1.3-fold (0.12 log units) above the measured number; the range from low to high includes it.
By their numbers in this assay, from the lowest: compounds 3 and 2 (each within the scatter of the next); then compound 4. At a limit, above all of these: compound 1.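

In this assay, 2-chlorophenyl on the amide-type nitrogen gives a real number rather than a limit, and that number stands clearly behind both partners carrying a group named with a 4: a 4.4-fold higher number from compound 3 to compound 4 (0.65 log units; beyond the scatter) and a 2.5-fold higher number from compound 2 to compound 4 (0.39 log units; beyond the scatter). Across the four compounds, those carrying 2-chlorophenyl or 2-methylphenyl therefore give higher numbers than those carrying 4-methoxyphenyl or 4-(tert-butyl)phenyl, and none of the four goes against this. The exchange of chloro for methyl on the aromatic carbon stays unresolved, with an at least 1.6-fold lower number from compound 1 to compound 4 (0.21 log units; that floor lies within the scatter), and compound 1 itself remains a limit of the assay: the limit of > 50000 nM in this assay, at which 1 of the 4 values shown sits.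

The compounds shown leave open whether this split follows the place of the group on the phenyl or the identity of the group, a question that 4-chlorophenyl on the same nitrogen would address directly against compound 4. They also do not tell how a plain phenyl, or a phenyl carrying an amine or a carboxylic acid, would behave on this nitrogen in this assay.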